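This account rests on a few compounds, and the source may have more. Where it says the series, first, only, none or still open, it means among the compounds named here.

Three thiosemicarbazones built on the same core have been tested, and a fourth is to follow. Compound 1 `C/C(=N\NC(=S)Nc1ccc(Cl)cc1)c1ccccn1`, compound 2 `C/C(=N/NC(=S)Nc1ccccc1[N+](=O)[O-])c1ccccn1` and compound 3 `C/C(=N\NC(=S)Nc1ccc([N+](=O)[O-])cc1)c1ccccn1` differ only in the group that sits on the outer benzene ring and in where that group stands. In a functional assay on MCF7 cells (Homo sapiens) for cytotoxicity, read by MTT assay, with a stated time of 48 h (a higher number here means a weaker inhibitor, a lower number a stronger inhibitor), compound 1 gives 8.49 nM, compound 2 gives 5.7 nM, and compound 3 gives 52 nM. The values of compound 1 and compound 2 lie within the usual scatter of each other, so no order can be read between them. Compound 2 and compound 3 share the same atoms joined differently; the difference between the two cores is not broken down here.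

One change has already been measured once. From compound 3 to compound 1 the change chloro in place of nitro on an aromatic carbon gave a 6.1-fold lower number from compound 3 to compound 1 (0.79 log units; beyond the scatter). Compound 4 `C/C(=N/NC(=S)Nc1ccccc1Cl)c1ccccn1` is compound 2 carried through the same kind of change, (chloro in place of nitro on an aromatic carbon); the group is placed ortho to a large group here, where in compound 1 it stood para to a large group, so the surroundings of the swap are not identical.

The expectation for compound 4 rests on the measured step from compound 3 to compound 1, tempered by the different place and by compound 2 already giving a low value. The step from compound 2 to compound 4 is expected to be a 2.3-fold lower number from compound 2 to compound 4 (0.36 log units; beyond the scatter). In this assay compound 4 is estimated to give 2.5 nM, with a likely range from 0.8 nM to 8 nM.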

Compound 4, half-maximal inhibitory concentration: 0.16 nM
Compound 4: middle estimate off by 16-fold (1.19 log units), on the high side; measured number below the stated range.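

In this assay, putting chloro in place of nitro gave a 36-fold lower number from compound 2 to compound 4 (1.55 log units; beyond the scatter), so on both cores shown this swap lowers the number, which means a stronger inhibitor. The direction carries over from one core to the other, but the size of the step does not: the same change on two cores in this assay, a 6.1-fold lower number (0.79 log units; beyond the scatter) from compound 3 to compound 1 and a 36-fold lower number (1.55 log units; beyond the scatter) from compound 2 to compound 4, 5.8-fold (0.76 log units) apart, beyond the scatter of two such steps Two pairs cannot show what sets the size of the step or predict it on a third core: the chloro stands ortho to a large group in compound 4 but not in compound 1, and this placement cannot be separated from the other differences between the two cores.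

The compounds shown leave open how an amine, a methoxy group or a bromo group would compare with chloro and nitro on the same outer ring. Also open, as far as these compounds go, is how the swap would behave at a third place on that ring, which could help show whether the size of the step follows the group's position.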